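A few compounds are considered here, and "the series" means these few. Any claim that something is new, unique, unknown or untested is made for them only; others in the source may bear on it.

Measured compounds in a functional assay (aorta) with Rattus norvegicus as the target; a lower number here means a stronger inhibitor, a higher number a weaker inhibitor:
- compound 1 `CC(C)c1cn2ccccc2c1S(=O)(=O)c1ccc(OCCCN2CCC(c3ccccc3)CC2)cc1`: 80.9 nM
- compound 2 `CCCN(CCC)CCCOc1ccc(S(=O)(=O)c2c(C)cn3ccccc23)cc1`: 957 nM
- compound 3 `CCCCc1cn2ccccc2c1S(=O)(=O)c1ccc(OCCCN(CCC)CCC)cc1`: 570 nM

Compound 1 gives the lowest number of the three in this assay; compound 3 and compound 2 both give higher numbers, and both gaps lie beyond the scatter.

Compound 4 `CC(C)c1cn2ccccc2c1S(=O)(=O)c1ccc(OCCCNC(C)(C)C)cc1` has not yet been measured. Relative to compound 1 the change is (tert-butyl)amino in place of 4-phenylpiperidin-1-yl on a saturated chain carbon, three bonds along the chain from an oxygen on an aromatic ring.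

Going by the values given here, the one measured step, a 1.7-fold lower number from compound 2 to compound 3 (0.23 log units; within the scatter), concerns the chain on the core and not the amine end of the linker, so it does not bear on this change. What remains is a comparison of values only: compound 1 carries the 4-phenylpiperidin-1-yl group and gives 80.9 nM, while compound 3, with a different amine and a different core chain, gives 570 nM. Two places differ between them. The share of the amine in that gap cannot be separated from the share of the core chain.

Since compound 4 gives up the 4-phenylpiperidin-1-yl group, a higher number than compound 1 is expected, with a step of about a 7.4-fold higher number from compound 1 to compound 4 (0.87 log units; beyond the scatter). The estimate for compound 4 is 600 nM, expected to fall between 150 nM and 2500 nM.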

Compound 4, half-maximal inhibitory concentration: 41.8 nM
For compound 4 the middle estimate is 14-fold (1.16 log units) above the measured one; the measured number lies below the stated range.
By their numbers in this assay, from the lowest: compounds 4 and 1 (each within the scatter of the next); then compounds 3 and 2 (each within the scatter of the next).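

In this assay, (tert-butyl)amino in place of 4-phenylpiperidin-1-yl at this position gives a 1.9-fold lower number from compound 1 to compound 4 (0.29 log units; within the scatter), so the two compounds cannot be told apart. On this core, then, neither ring of the 4-phenylpiperidin-1-yl group is needed for a value in this range: compound 4 has no ring in this group and carries a hydrogen-bond donor absent from the group in compound 1, yet the step stays within the scatter. Nothing at hand accounts for this result.

Open, as far as these compounds go, is how a dipropylamino or an isopropylamino group would read at this position on the core of compound 1. Also open, from the compounds shown here alone, is whether the same exchange would stay within the scatter on a core carrying the butyl chain of compound 3.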